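The source may hold more compounds than are shown below. What is called first, only, known or untested is meant among the compounds shown, and "the series" means these compounds.

Measured compounds:
- compound 1 `Cc1cc(OCC(C)C)cc(C)c1-c1cccc(COc2ccc(OCC(=O)O)c(F)c2)c1`: "not determined" (no result reported) in a functional assay on CHO cells for agonist activity at Free fatty acid receptor 1 (Homo sapiens), read by FLIPR and calcium flux; a lower number here means that less compound is needed, a higher number that more compound is needed for the effect
- compound 2 `Cc1cc(O)cc(C)c1-c1cccc(COc2ccc(OCC(=O)O)c(F)c2)c1`: 110 nM
- compound 3 `CC(=O)N(CC(=O)O)c1ccc(OCc2cccc(-c3c(C)cc(OCCCS(C)(=O)=O)cc3C)c2)cc1`: "not determined" (no result reported) in this assay

Compound 1 stands without a number in this assay; compound 3 likewise carries no result, so the only anchor in the series is compound 2, which in this assay gives 110 nM. Compound 4 `Cc1cc(OCCCO)cc(C)c1-c1cccc(COc2ccc(OCC(=O)O)c(F)c2)c1` is the next compound to be run in this assay. It departs from compound 1 in one place: 2-hydroxyethyl in place of isopropyl on a saturated chain carbon bound to an oxygen on an aromatic ring. Within the data shown here, no step between measured compounds exists here, so the size of the step from compound 1 to compound 4 in this assay cannot be read from a measured pair. What the series offers is that compound 2 carries a hydroxyl on the same ring as the isobutoxy of compound 1. In this assay compound 2 gives 110 nM; a 3-hydroxypropoxy at that position is expected to sit in a similar region, with no direction of change to be asserted beyond the scatter. Compound 4 is therefore estimated at 150 nM, with a range from 40 nM to 600 nM.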

Compound 4, half-maximal effective concentration: 110 nM
Beside the measured number, compound 4's estimate is 1.4-fold (0.13 log units) above it; low and high end bracket the measured number.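

In this assay the position gives its first readable step, no change at the digits printed from compound 2 to compound 4 (within the scatter), with 3-hydroxypropyl in place of hydrogen on an oxygen on an aromatic ring. On the core of compound 2, this position therefore accepts the 3-hydroxypropyl chain with no measurable loss or gain. The change from isobutyl to 3-hydroxypropyl between compound 1 and compound 4 cannot be read, since compound 1 has no number, and nothing measured here speaks to the reason for the flat step.

Open, as far as these compounds go, is whether the terminal hydroxyl of compound 4 has any part in this result, which a 3-methoxypropyl or a plain propyl at the same oxygen would test. Also open, from the compounds shown here alone, is how far the flat step extends, for instance to a longer chain ending in a hydroxyl, an amine or a carboxylic acid.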